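Swapping a Nitrophenyl for a Fluorophenyl on a Ring Carbon

The source may hold more compounds than are shown below. What is called first, only, known or untested is meant among the compounds shown, and "the series" means these compounds.

In a functional assay on the whole organism (strain albino) for inhibition, with Rattus norvegicus as the target, read by paw edema, with stated times of 1 h and 4 h, at a dose of 200 mg/kg by the oral route (a lower number here means less inhibition, a higher number more inhibition at the dose given (going by the name of the read-out)), compound 3 `O=c1oc2ccccc2cc1C1=NN(c2ccccc2)[C@@H](c2cccc([N+](=O)[O-])c2)C1` gives 31.2%, the lowest of the three numbers measured. Compound 1 `O=c1oc2ccccc2cc1C1=NN(c2ccccc2)[C@@H](/C=C/c2ccccc2)C1` gives 42.5%, and compound 2 `O=c1oc2ccccc2cc1C1=NN(c2ccccc2)[C@@H](c2ccc(Cl)cc2)C1` gives 64.7%. The step from compound 3 to compound 4 `O=c1oc2ccccc2cc1C1=NN(c2ccccc2)[C@@H](c2ccc(F)cc2)C1` is 4-fluorophenyl in place of 3-nitrophenyl on a saturated ring carbon. The measured step that bears most on it runs the other way: a number 33.5 percentage points lower from compound 2 to compound 3 (beyond the scatter). For the measured compounds named here, compound 4 carries a halogen on the same saturated ring carbon as compound 2, so a rise back toward that value is expected, though no fluorine-bearing compound has been measured yet. The smaller step of a number 11.3 percentage points lower from compound 1 to compound 3 (beyond the scatter) also places 3-nitrophenyl under 2-phenylethenyl. Compound 4 is therefore expected to show a number 23.8 percentage points higher from compound 3 to compound 4 (beyond the scatter), giving an estimate of 55% with a range from 40% to 70%.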

Compound 4, a percentage reported as inhibition, in the whole organism at one dose (the size of the read-out at that dose, not a potency): 66.7%
Beside the measured number, compound 4's estimate is 11.7 percentage points below it; the measured number falls inside the stated range.
By their numbers in this assay, from the lowest: compound 3; then compound 1; then compounds 2 and 4 (each within the scatter of the next).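

In this assay, fluoro in place of chloro on the aromatic carbon leaves the read-out essentially unchanged, with a number 2 percentage points higher from compound 2 to compound 4 (within the scatter). The 4-fluorophenyl group also stands clear of the other two groups at this saturated ring carbon, with a number 35.5 percentage points higher from compound 3 to compound 4 (beyond the scatter) and a number 24.2 percentage points higher from compound 1 to compound 4 (beyond the scatter). No measurement at hand gives a reason for these steps.

From the compounds shown here alone, compound 4 differs from compound 3 in both the substituent and where it sits on the phenyl ring, so the contribution of each remains open. A 4-nitrophenyl group would separate the two, while a 4-methoxyphenyl group would show whether a non-halogen substituent can match the fluoro and chloro compounds.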